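The compounds below may be only part of what the source reports. "The series", "measured", "known", "first", "only" and "open" are said of these compounds alone.

Compound 1 `CC1=C(C(=O)OCc2ccccc2)C(c2cccs2)NC(=S)N1` gives 24% in an assay on membranes from HeLa cells for displacement of a labelled ligand from adenosine receptor A3 (Homo sapiens), read by scintillation counting, with a stated time of 180 min, tested at 1 uM; a lower number here means less inhibition, a higher number more inhibition at the concentration tested (going by the name of the read-out).
Compound 2 `CC1=C(C(=O)OCC(C)C)C(c2ccsc2)NC(=S)N1` gives 2% in this assay.

Compound 2 stands lowest of the two numbers, and compound 1 sits higher by a gap beyond the usual scatter. Compound 3 `CC1=C(C(=O)OCc2ccccc2)C(c2ccsc2)NC(=S)N1` has not been measured. It changes compound 2 in one place: phenyl in place of isopropyl on a saturated chain carbon bound to an oxygen next to a carbonyl group. Compound 1 already carries the benzyl group and gives 24%, so a rise is expected in this assay, although the two measured compounds differ in a second place as well, so the size is uncertain. The expected step is a number 13 percentage points higher from compound 2 to compound 3 (beyond the scatter). For compound 3 the estimated value is 15%, within 2% to 35%.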

Compound 3, a percentage reported as inhibition, at one concentration (the size of the read-out at that concentration, not a potency): 2%
Beside the measured number, compound 3's estimate is 13 percentage points above it; low and high end bracket the measured number.
By their numbers in this assay, from the lowest: compounds 2 and 3 (each within the scatter of the next); then compound 1.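

Phenyl in place of isopropyl on a saturated chain carbon bound to an oxygen next to a carbonyl group gives no change at the digits printed from compound 2 to compound 3 (within the scatter) in this assay, so with thiophen-3-yl present, this change does not move the number. With the benzyl group held fixed, thiophen-3-yl in place of thiophen-2-yl on a saturated ring carbon gives a number 22 percentage points lower from compound 1 to compound 3 (beyond the scatter), so the thiophene attachment does matter here. Nothing measured here explains either step.

On these data alone, it remains open whether isobutyl and benzyl would also read alike with thiophen-2-yl present, and how an amine or a carboxylic acid at this place would read.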